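This account rests on a few compounds, and the source may have more. Where it says the series, first, only, none or still open, it means among the compounds named here.

Three compounds have so far been measured in an ADME assay on MCF-10A cells (Homo sapiens) for cytotoxicity, read by MTT assay, with a stated time of 72 h; a lower number here means a stronger inhibitor of growth, a higher number a weaker inhibitor of growth:

Compound 1, `C[Se]/C(=N\C(=O)c1cc2ccccc2s1)NC(=O)c1cc2ccccc2s1`, gives 490 nM.
Compound 2, `C[Se]/C(=N\C(=O)c1cccs1)NC(=O)c1cccs1`, gives 9260 nM.
Compound 3, `CS/C(=N\C(=O)c1csc([N+](=O)[O-])c1)NC(=O)c1csc([N+](=O)[O-])c1`, gives 1550 nM.

Compound 3 stands second highest of these three numbers. Its nearest neighbour is compound 1, whose number is lower by a gap beyond the usual scatter; compound 2 lies furthest away, with a higher number, again beyond the scatter. All three share a central carbon with a double bond to nitrogen, flanked by two amide-type nitrogens, but they differ both in their aromatic ends and in what sits on that carbon, and no two of them differ in one place only, so no single change has yet been isolated.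

Compound 4, `O=C(/N=C(/NC(=O)c1csc([N+](=O)[O-])c1)[Se]Cc1ccccc1)c1csc([N+](=O)[O-])c1`, has not yet been measured in this assay. It differs from compound 3 in one place: a group of 8 heavy atoms (7 carbon, 1 selenium; one six-membered aromatic ring of carbon only) in place of a group of 2 heavy atoms (1 carbon, 1 sulfur; no ring), on a carbon with a double bond to nitrogen. Within the data shown here, with no measured step of this kind to lean on, the expectation is a moderate move towards a lower number, because compound 1, which also carries selenium on that carbon, gives 490 nM, the lowest number of the three. For compound 4 the estimate is 600 nM, within a range of 200 nM to 2500 nM, which corresponds to an expected step of a 2.6-fold lower number from compound 3 to compound 4 (0.41 log units; beyond the scatter).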

Compound 4, concentration for 50% growth inhibition: 24400 nM
Estimate against measurement, compound 4: 41-fold (1.61 log units) below; the measured number lies above the stated range.
By their numbers in this assay, from the lowest: compound 1; then compound 3; then compound 2; then compound 4.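

In this assay, the group on the carbon with a double bond to nitrogen clearly matters: with the aromatic ends left unchanged, replacing methylsulfanyl with the selenium group that carries a six-membered aromatic ring gives a 16-fold higher number from compound 3 to compound 4 (1.20 log units; beyond the scatter), a large step towards weaker inhibition of growth. The result also shows that selenium on this carbon does not by itself ensure a low number, since the selenium-bearing compound 4 sits well above the sulfur-bearing compound 3. Nothing measured here explains why the step is so large.

This single step changes two things at once, the sulfur for selenium and the small methyl end for an end with an aromatic ring, so the compounds shown cannot separate the contribution of each. A plain methyl group on selenium, or the same ring-bearing group on sulfur, with the aromatic ends of compound 3 would separate them, while a longer alkyl chain or an amine on that carbon would show how far the number follows the group placed there.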